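A fluorobenzyl swap on a dichlorobenzyl sulfonamide

The source may report more compounds than this note shows. Statements on the series, on what has been measured and on what is new or still open speak of the compounds shown alone.

compound 1 `CC1OC(=O)c2cc(C#N)c(N3CC(C(=O)NS(=O)(=O)Cc4ccccc4)C3)nc21`: > 300000 nM
compound 2 `CC1(C(=O)NS(=O)(=O)c2ccc(Cl)s2)CCN(c2nc3c(cc2C#N)C(=O)OC3)CC1`: 1640 nM
compound 3 `N#Cc1cc2c(nc1N1CCC(C(=O)NS(=O)(=O)Cc3cc(Cl)cc(Cl)c3)CC1)COC2=O`: 30500 nM

In a functional assay (Platelet, plasma) for inhibition, with Homo sapiens as the target (on this read-out higher numbers stand for weaker inhibition and lower numbers for stronger inhibition), compound 3 gives 30500 nM, the higher of the two true numbers, while compound 2 gives 1640 nM, lower by more than the usual scatter. For compound 1 the result is only a limit of the assay, > 300000 nM.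

The next compound to be tested is compound 4 `N#Cc1cc2c(nc1N1CCC(C(=O)NS(=O)(=O)Cc3ccccc3F)CC1)COC2=O`. It carries 2-fluorophenyl in place of 3,5-dichlorophenyl on a saturated chain carbon bound to a sulfonyl sulfur, so that 3,5-dichlorobenzyl gives way to 2-fluorobenzyl: 2-fluorophenyl in place of 3,5-dichlorophenyl on a saturated chain carbon bound to a sulfonyl sulfur. Among the compounds with values here, no measured pair isolates a change at this place. Within the data shown here, the expectation therefore rests on compound 3 at 30500 nM, the only measured compound with a halogen-bearing benzyl group. The expected step of a 1.2-fold lower number from compound 3 to compound 4 (0.09 log units; within the scatter) is none beyond the scatter, though with wide uncertainty in either direction. For compound 4 the estimated value is 25000 nM, with an expected range of 6000 nM to 100000 nM.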

Compound 4, half-maximal inhibitory concentration: 23700 nM
Compound 4: the middle estimate sits 1.1-fold (0.02 log units) above what was measured; measured number inside the range.
By their numbers in this assay, from the lowest: compound 2; then compounds 4 and 3 (each within the scatter of the next). At a limit, above all of these: compound 1.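

Within the data shown here, this is the first step read at this place, on a saturated chain carbon bound to a sulfonyl sulfur: in this assay, 2-fluorophenyl in place of 3,5-dichlorophenyl gives a 1.3-fold lower number from compound 3 to compound 4 (0.11 log units; within the scatter) and so no readable change. Both chlorine atoms leave and a single fluorine enters, with one heavy atom fewer, yet compound 3 and compound 4 cannot be told apart on this read-out. The swap alters the number, kind and placement of the halogens all at once, so the result applies to the exchange as a whole and assigns nothing to any one of these.

From the compounds shown here alone, whether an amine or a carboxylic acid on the phenyl ring, or a longer chain before it, would move the number remains open. Nothing measured here says why these two benzyl groups read alike.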